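The source may report more compounds than this note shows. Statements on the series, on what has been measured and on what is new or still open speak of the compounds shown alone.

The measured compounds:
compound 1, `ClCc1cccc(Cn2cnc3ncnc(Cl)c32)c1`: 5490 nM
compound 2, `ClCc1ccc(Cn2cnc3nc(Cl)nc(Cl)c32)cc1`: 5490 nM
compound 3, `ClCc1cccc(Cn2cnc3nc(Cl)nc(Cl)c32)c1`: 15100 nM

All three were tested in a functional assay on UACC-257 cells (Homo sapiens) for cytotoxicity, read by sulforhodamine B assay, with a stated time of 48 h; a lower number here means a stronger inhibitor of growth, a higher number a weaker inhibitor of growth. In this assay compound 2 gives 5490 nM, level with compound 1 at the digits shown, and these two together hold the lowest numbers of the three. Compound 3 shows a higher number than compound 2, but the difference between the two cores is not broken down here, so only the two values themselves speak for that pair. Compound 3 and compound 1 are joined by a single counted change, (hydrogen in place of chloro on an aromatic carbon), and in this assay that change gave a 2.8-fold lower number from compound 3 to compound 1 (0.44 log units; beyond the scatter), a modest step that lies beyond the scatter.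

Compound 4, `ClCc1ccc(Cn2cnc3ncnc(Cl)c32)cc1`, has not yet been measured in this assay. It differs from compound 2 by hydrogen in place of chloro on an aromatic carbon, which is the same change, at the same kind of place, as that leading from compound 3 to compound 1. A step of about the same size is therefore expected here. This expectation rests on the one earlier case, a 2.8-fold lower number from compound 3 to compound 1 (0.44 log units; beyond the scatter), and on nothing more, so it is held loosely. The step expected for compound 4 is a 2.7-fold lower number from compound 2 to compound 4 (0.44 log units; beyond the scatter). Compound 4 is estimated to give 2000 nM in this assay, with a plausible range from 900 nM to 4500 nM.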

Compound 4, concentration for total growth inhibition: 3460 nM
Beside the measured number, compound 4's estimate is 1.7-fold (0.24 log units) below it; the measured number falls inside the stated range.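

In this assay, hydrogen in place of chloro on an aromatic carbon, between two ring nitrogen atoms, gives a 1.6-fold lower number from compound 2 to compound 4 (0.20 log units; within the scatter), a step that cannot be told apart from the spread of repeated measurements when taken alone. Set beside the earlier case, the two steps cannot be told apart in size, so nothing here suggests that the core changes what this replacement does: the same change on two cores in this assay, a 2.8-fold lower number (0.44 log units; beyond the scatter) from compound 3 to compound 1 and a 1.6-fold lower number (0.20 log units; within the scatter) from compound 2 to compound 4, 1.7-fold (0.24 log units) apart, within the scatter of two such steps This shows only that the two results are compatible with a single modest effect carried from one core to the other; it does not show that the effect is real on both cores, as only the step from compound 3 to compound 1 lies beyond the scatter, and two pairs make no rule for the series.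

The compounds shown leave open what an amine, a methoxy group or a fluoro group would give on that same aromatic carbon, where only chloro and hydrogen appear here. They also leave open how the numbers would respond if the chloromethyl group gave way to a hydroxymethyl group or a longer chain.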